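A second sulfur group on the same core

The source may hold more compounds than are shown below. What is called first, only, known or untested is meant among the compounds shown, and "the series" means these compounds.

Measured so far in an ADME assay on Huh7.5.1 cells (Homo sapiens) for cytotoxicity, read by WST assay, with a stated time of 48 h (a lower number here means that less compound is tolerated, a higher number that more compound is tolerated), for half-maximal cytotoxic concentration:
- compound 1 `Cc1c(-c2ccc(Cc3ccc(C(O)C(F)(F)F)cc3)cc2)[nH]c2cccc(F)c2c1=O` gives > 10000 nM (a limit)
- compound 2 `CN=S(=O)(c1ccc(Cc2ccc(-c3[nH]c4cccc(F)c4c(=O)c3C)cc2)cc1)C(F)(F)F` gives > 10000 nM (a limit)

Compound 2 stands at > 10000 nM, a limit of the assay and not a number. Within the data shown here, the picture so far is the limit of > 10000 nM in this assay, at which 2 of the 2 values shown sit, and no measured compound gives a number. Compound 3 `Cc1c(-c2ccc(Cc3ccc(S(F)(F)(F)(F)F)cc3)cc2)[nH]c2cccc(F)c2c1=O` differs from compound 2 in one place: a group of 6 heavy atoms (5 fluorine, 1 sulfur; no ring) in place of a group of 8 heavy atoms (2 carbon, 1 nitrogen, 1 oxygen, 3 fluorine, 1 sulfur; no ring), on an aromatic carbon. Among the measured compounds shown here, the one measured step that bears on this is a step that the two limits leave unreadable from compound 1 to compound 2, also an exchange of a group on an aromatic carbon, and it offers no size to carry over. The expectation rests on compound 2 , whose limit is > 10000 nM, so no step beyond the scatter is expected in this assay. The expected change is a step that the limit leaves unreadable from compound 2 to compound 3, with no firm direction. Compound 3 is estimated at 15000 nM (7000 nM to 30000 nM).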

Compound 3, half-maximal cytotoxic concentration: > 5000 nM
Compound 3: no number, only a limit; the forecaster's own chance of this, stated with the estimate: 85%; the middle value is on the limit's open side.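

In this assay compound 3 gives > 5000 nM, a limit of the assay and not a number. The steps among compound 1, compound 2 and compound 3 cannot be read, as all three values are limits. The compounds shown leave open at what concentration any of the three reaches half-maximal cytotoxicity in this assay.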